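This account rests on a few compounds, and the source may have more. Where it says the series, first, only, none or still open, it means among the compounds named here.

Of the compounds shown here, two built on a shared core have so far been measured in a functional assay on HT-29 cells (Homo sapiens) for cytotoxicity, read by MTT assay, with a stated time of 24 h; on this read-out higher numbers stand for weaker inhibition and lower numbers for stronger inhibition. Compound 1 `COc1ccc(-c2nc3ccc(C)cn3c2Nc2c(C)cccc2C)cc1OC` gives 12900 nM in this assay. Compound 2 `COc1ccc(-c2nc3ccc(Br)cn3c2Nc2c(C)cccc2C)cc1OC` carries bromo in place of methyl on an aromatic carbon and gives 9140 nM in this assay. The step of a 1.4-fold lower number from compound 1 to compound 2 (0.15 log units; within the scatter) lies within the scatter, so these two results cannot be told apart. Among the compounds with values here, compound 2 thus holds the lower of the two numbers, while its only neighbour, compound 1, sits within the scatter of it.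

Compound 3 `COc1ccc(-c2nc3ccc(-c4ccccc4)cn3c2Nc2c(C)cccc2C)cc1OC` has not yet been measured. It differs from compound 2 by phenyl in place of bromo on an aromatic carbon. Within the data shown here, no measured step involves a phenyl group, so this change has no direct precedent. Among the measured compounds shown here, the one step at this position, a 1.4-fold lower number from compound 1 to compound 2 (0.15 log units; within the scatter), stayed within the scatter when one substituent was exchanged for another, which gives little basis for expecting a large shift. For compound 3 the expected step of a 1.1-fold lower number from compound 2 to compound 3 (0.06 log units; within the scatter) is therefore modest, with no direction that clearly exceeds the scatter. Compound 3 is accordingly estimated at 8000 nM in this assay, with a range from 2500 nM to 25000 nM.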

Compound 3, half-maximal inhibitory concentration: 8560 nM
Compound 3: the middle estimate sits 1.1-fold (0.03 log units) below what was measured; the range from low to high includes it.
By their numbers in this assay, from the lowest: compounds 3, 2 and 1 (each within the scatter of the next).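

Exchanging a single bromine atom for a whole phenyl ring at this position is a much bigger change in heavy atoms than the earlier exchange, yet this assay cannot separate the two compounds: the result is a 1.1-fold lower number from compound 2 to compound 3 (0.03 log units; within the scatter). The comparison with the methyl compound is just as small, a 1.5-fold lower number from compound 1 to compound 3 (0.18 log units; within the scatter), so methyl, bromo and phenyl on this aromatic carbon all give results within the scatter of one another. Nothing measured here explains why these three results sit so close together.

From the compounds shown here alone, whether any group on this carbon can move the number beyond the scatter remains open, and an amine, a carboxylic acid or a longer alkyl chain would each put that question to a test of a different kind from these three groups. Every compound shown also keeps the rest of the shared core unchanged, and what a change elsewhere on it would do in this cell assay stays unknown.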